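A few compounds are considered here, and "the series" means these few. Any claim that something is new, unique, unknown or untested is made for them only; others in the source may bear on it.

Working notes on the diaryl-naphthyl series.

Compound 1 `COc1ccc(C(c2ccc(OC(C)CN(C)C)cc2)c2cccc3ccccc23)c(OC)c1OC` is measured in a functional assay on MCF7 cells (Homo sapiens) for inhibition, read by sulforhodamine B assay, with a stated time of 48 h (on this read-out higher numbers stand for weaker inhibition and lower numbers for stronger inhibition), where compound 1 gives 13100 nM. Two further members of the same core have numbers on this read-out: compound 2 `COc1ccc(/C(=C/c2ccc(F)cc2)c2cccc3ccccc23)c(OC)c1OC` gives 10500 nM, and compound 3 `COc1ccc(C(O)(C/C=C\c2ccccc2)c2cccc3ccccc23)c(OC)c1OC` gives 10200 nM. The three numbers lie within the usual scatter of one another, so compound 1 cannot be set apart from compound 2 or compound 3 on what is shown; none of these pairs forms a single-point step, and only the bare values can be compared.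

Compound 4 `COc1ccc(C(c2ccc(OCC(=O)O)cc2)c2cccc3ccccc23)c(OC)c1OC` has not yet been measured in this assay. It differs from compound 1 in one place: carboxymethyl in place of 1-((dimethylamino)methyl)ethyl on an oxygen on an aromatic ring. For the measured compounds named here, no measured pair carries a change of this kind, so there is no step to lean on for its size or direction. The expectation is written from the values of the three measured compounds alone.

For compound 4 in this assay the number is expected to move as a 1.9-fold higher number from compound 1 to compound 4 (0.28 log units; within the scatter), leaning towards weaker inhibition, with the possibility that the step stays within the scatter. The estimate for compound 4 is 25000 nM, with a range from 8000 nM to 80000 nM.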

Compound 4, half-maximal inhibitory concentration: > 20000 nM
Compound 4 was reported as a limit (the forecaster's own chance of this, stated with the estimate: 20%); the middle value lies beyond the limit too.
By their numbers in this assay, from the lowest: compounds 3, 2 and 1 (each within the scatter of the next). At a limit, above all of these: compound 4.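

In this assay, compound 4 is reported only as a limit, > 20000 nM. Carboxymethyl in place of 1-((dimethylamino)methyl)ethyl on an oxygen on an aromatic ring gives an at least 1.5-fold higher number from compound 1 to compound 4 (0.18 log units; that floor lies within the scatter), which is the only single-place step in the series so far and the first reading of this position, since the earlier compounds offered only bare values with no step between them. The step shows no move towards stronger inhibition with this change, but because its floor lies within the scatter, it does not set compound 4 apart from compound 1, and its full size and the exact value of compound 4 stay unknown: the limit of > 20000 nM in this assay, at which 1 of the 4 values shown sits.

The compounds shown do not separate the loss of the dimethylamino group from the arrival of the carboxylic acid, so a neutral group such as a methyl ester or a primary amide on the same short chain would be needed to tell these apart. Also open, going by these compounds, is how the number responds to chain shape at this oxygen, for example an unbranched dimethylaminoethyl chain, a longer carboxylic acid chain or a morpholine at the chain end.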